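Series notes: bromo in place of nitro on compound 3

The source may hold more compounds than are shown below. What is called first, only, known or untested is meant among the compounds shown, and "the series" means these compounds.

Of the compounds shown here, three sharing one core have been measured in a functional assay on CCRF-CEM cells (Homo sapiens) for antiproliferative activity; on this read-out lower numbers stand for stronger inhibition and higher numbers for weaker inhibition. Compound 1 `COc1cc(C(=O)c2sc(-c3cc(OC)c(OC)c(OC)c3)cc2N)cc(OC)c1OC` gives 840 nM. Compound 2 `CCOc1ccc(-c2cc(N)c(C(=O)c3cc(OC)c(OC)c(OC)c3)s2)cc1` gives 270 nM. Compound 3 `COc1cc(C(=O)c2sc(-c3ccc([N+](=O)[O-])cc3)cc2N)cc(OC)c1OC` gives 99 nM, the lowest of the three numbers; compound 2 comes nearest and compound 1 lies furthest. Among the compounds with values here, the one single-point step among the measured compounds, a 2.7-fold lower number from compound 2 to compound 3 (0.44 log units; beyond the scatter), is nitro in place of ethoxy on an aromatic carbon.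

Compound 4 `COc1cc(C(=O)c2sc(-c3ccc(Br)cc3)cc2N)cc(OC)c1OC` is not yet measured. It differs from compound 3 as follows: bromo in place of nitro on an aromatic carbon. Within the data shown here, no measured step concerns a bromo group, and the only step at this aromatic carbon, a 2.7-fold lower number from compound 2 to compound 3 (0.44 log units; beyond the scatter), exchanges ethoxy for nitro rather than nitro for bromo, so it gives no direct guide to the size or direction of the coming step. The groups that have occupied this carbon span values from compound 2 at 270 nM to compound 3 at 99 nM. For compound 4 the expectation is a number within that span, most likely somewhat higher than that of the nitro compound, so a step of a 2.0-fold higher number from compound 3 to compound 4 (0.31 log units; beyond the scatter) is expected. Compound 4 is estimated at 200 nM in this assay, with a range of 60 nM to 700 nM.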

Compound 4, half-maximal inhibitory concentration: 86 nM
The estimate for compound 4 lay 2.3-fold (0.37 log units) above the measured number; measured number inside the range.
By their numbers in this assay, from the lowest: compounds 4 and 3 (each within the scatter of the next); then compound 2; then compound 1.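

In this assay the exchange of 4-nitrophenyl for 4-bromophenyl gives a 1.2-fold lower number from compound 3 to compound 4 (0.06 log units; within the scatter), so at this aromatic carbon a nitro group with 3 heavy atoms and 2 hydrogen-bond acceptors and a bromo group with 1 heavy atom and no hydrogen-bond acceptors cannot be told apart on this read-out. The ethoxy group of compound 2 now stands apart from two different groups rather than one: a 3.1-fold lower number from compound 2 to compound 4 (0.50 log units; beyond the scatter) adds to the earlier 2.7-fold lower number from compound 2 to compound 3 (0.44 log units; beyond the scatter), and both steps lie beyond the scatter. No evidence at hand bears on why the nitro and bromo compounds read alike or why the ethoxy compound reads apart from them.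

As far as these compounds go, whether other groups on this carbon would fall with nitro and bromo or with ethoxy remains open, and an amine or a carboxylic acid at this place would test that. From the compounds shown here alone, it also remains open whether the gap belongs to ethoxy alone or extends to a longer chain joined through oxygen, such as propoxy.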